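Amine side chain variation and cytotoxicity across the series

A few compounds are considered here, and "the series" means these few. Any claim that something is new, unique, unknown or untested is made for them only; others in the source may bear on it.

Compounds 1, 2 and 3 share one core and differ only in the group on the nitrogen on the aromatic ring. Compound 1 `CCNc1nc(C)c(-c2nc3ccccc3s2)c(N[C@@H]2C[C@H](CO)[C@@H](O)[C@H]2O)n1` gives 12000 nM in an ADME assay on cells (Homo sapiens) for cytotoxicity, read by polymerase chain reaction, with a stated time of 3 days; on this read-out higher numbers stand for lower toxicity in this test and lower numbers for higher toxicity in this test. Compound 2 `Cc1nc(NC(C)C)nc(N[C@@H]2C[C@H](CO)[C@@H](O)[C@H]2O)c1-c1nc2ccccc2s1` gives 13000 nM in this assay. Compound 3 `Cc1nc(NCC(C)C)nc(N[C@@H]2C[C@H](CO)[C@@H](O)[C@H]2O)c1-c1nc2ccccc2s1` gives 10000 nM in this assay; this is the lowest of the three numbers, but its gaps to the other two lie within the scatter, so no order among them can be read. The steps measured so far, a 1.1-fold higher number from compound 1 to compound 2 (0.03 log units; within the scatter), a 1.2-fold lower number from compound 1 to compound 3 (0.08 log units; within the scatter) and a 1.3-fold lower number from compound 2 to compound 3 (0.11 log units; within the scatter), all sit within the scatter.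

Compound 4 `CCOCCNc1nc(C)c(-c2nc3ccccc3s2)c(N[C@@H]2C[C@H](CO)[C@@H](O)[C@H]2O)n1` has not yet been measured. It differs from compound 3 by ethoxymethyl in place of isopropyl on a saturated chain carbon bound to a nitrogen on an aromatic ring. All three measured steps alter the same side chain and none of them moved the number beyond the scatter, so the step of a 1.1-fold higher number from compound 3 to compound 4 (0.04 log units; within the scatter) is expected to remain within the scatter as well. On that basis compound 4 is estimated at 11000 nM in this assay, with a range from 5000 nM to 25000 nM.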

Compound 4, half-maximal cytotoxic concentration: 18000 nM
Compound 4: the middle estimate sits 1.6-fold (0.21 log units) below what was measured; measured number inside the range.
By their numbers in this assay, from the lowest: compounds 3, 1, 2 and 4 (each within the scatter of the next).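

Even with the oxygen of the ethoxymethyl group in the side chain, the steps in this assay stay within the scatter: a 1.8-fold higher number from compound 3 to compound 4 (0.26 log units; within the scatter) and a 1.4-fold higher number from compound 2 to compound 4 (0.14 log units; within the scatter) and a 1.5-fold higher number from compound 1 to compound 4 (0.18 log units; within the scatter) are the three new steps. Within the data shown here, the earlier compounds carried only carbon chains on this nitrogen, so 2-ethoxyethyl is the first chain here to bring a hydrogen-bond acceptor to this place, and no shift in the number can be read from it. Nothing measured on these compounds offers an explanation for the numbers in this series.

Going by these compounds, whether a chain carrying a tertiary amine or a carboxylic acid, or a longer ether chain, would take the number in this assay beyond the scatter stays open. On these data alone, whether a change at any other place on the shared core would do so stays open as well.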